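A few compounds are considered here, and "the series" means these few. Any claim that something is new, unique, unknown or untested is made for them only; others in the source may bear on it.

Compound 1 `CN(C)C(=S)SCC(CSC(=S)N(C)C)C(=O)c1ccccc1F` gives 920 nM in a functional assay on NCI-H460 cells (Homo sapiens) for inhibition, read by MTT assay, with a stated time of 72 h; a higher number here means a weaker inhibitor, a lower number a stronger inhibitor. Compound 2 `CN(C)C(=S)SCC(CSC(=S)N(C)C)C(=O)c1cccnc1` gives 870 nM in this assay.

Compound 2 stands within the scatter of compound 1: the step of a 1.1-fold lower number from compound 1 to compound 2 (0.02 log units; within the scatter) is too small to separate the two, so neither can be called the stronger inhibitor. Compound 3 `CN(C)C(=S)SCC(CSC(=S)N(C)C)C(=O)c1nccs1` differs from compound 2 by one change: 1,3-thiazol-2-yl in place of pyridin-3-yl on a carbonyl carbon. For the measured compounds named here, the only measured step that bears on this change is the one from compound 1 to compound 2, which also swapped the aromatic group on the carbonyl carbon and left the number essentially unchanged, as a 1.1-fold lower number from compound 1 to compound 2 (0.02 log units; within the scatter) shows. On that basis the expected step of no change at the digits printed from compound 2 to compound 3 (within the scatter) in this assay is none beyond the scatter. Compound 3 is therefore estimated to give 870 nM in this assay, with a likely range from 400 nM to 1900 nM.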

Compound 3, half-maximal inhibitory concentration: 840 nM
Estimate against measurement, compound 3: 1.0-fold (0.02 log units) above, within the range that was stated.
By their numbers in this assay, from the lowest: compounds 3, 2 and 1 (each within the scatter of the next).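

In this assay, 1,3-thiazol-2-yl on the carbonyl carbon gives a 1.0-fold lower number from compound 2 to compound 3 (0.02 log units; within the scatter) when it replaces pyridin-3-yl and a 1.1-fold lower number from compound 1 to compound 3 (0.04 log units; within the scatter) when it replaces 2-fluorophenyl. For the compounds shown here, the earlier compounds showed only that two six-membered aromatic rings could not be separated at this position; the five-membered aromatic ring with 2 hetero atoms now cannot be separated from either of them, so all three groups remain within the scatter of one another. Nothing measured here accounts for this lack of separation.

The compounds shown leave open whether a group on the carbonyl carbon that is not aromatic, such as a cyclohexyl ring, a tertiary amine or a carboxylic acid, would shift the number beyond the scatter. They also leave open how a change elsewhere in the shared core would register in this assay.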